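This account rests on a few compounds, and the source may have more. Where it says the series, first, only, none or still open, it means among the compounds named here.

Measured compounds:
compound 1 `COc1ccc2nc(C)cc(OC(C)C(=O)Nc3cc(C)cc(C)c3)c2c1`, 5.76
compound 2 `COc1cccc(NC(=O)COc2cc(C)nc3ccc(OC)cc23)c1`, 4.49
compound 3 `COc1ccc2nc(C)cc(OCC(=O)Nc3ccc(Cl)c(C(F)(F)F)c3)c2c1`, 6.22

In a physicochemical assay for lipophilicity, read by HPLC, in phosphate buffer, measured as chromatographic lipophilicity, at pH 7.4 (a lower number here means a more polar compound, a higher number a more lipophilic compound), compound 2 gives 4.49, the lowest of the three numbers; compound 1 sits a good deal higher and compound 3 higher still, both gaps beyond the scatter. The step examined here leads from compound 2 to compound 4 `COc1ccc2nc(C)cc(OCC(=O)Nc3ccncn3)c2c1`. The change is pyrimidin-4-yl in place of 3-methoxyphenyl on an amide-type nitrogen, so one six-membered aromatic ring with 2 hetero atoms replaces one six-membered aromatic ring of carbon only on the amide-type nitrogen. Among the compounds with values here, no measured pair shows a change of this kind, so the size of the step is not fixed by data. Starting from compound 2 with 4.49, a downward step of a number 1.59 log units lower from compound 2 to compound 4 (beyond the scatter) is expected, well beyond the scatter. Compound 4 is therefore estimated at 2.9, between 2.2 and 3.6.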

Compound 4, distribution coefficient: 2.53
For compound 4 the middle estimate is 0.37 log units above the measured one; low and high end bracket the measured number.
By their numbers in this assay, from the lowest: compound 4; then compound 2; then compound 1; then compound 3.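

With pyrimidin-4-yl in place of 3-methoxyphenyl on the amide-type nitrogen, this assay shows a number 1.96 log units lower from compound 2 to compound 4 (beyond the scatter), so this one position alone can shift the number by a large amount. Compounds 1 and 3 differ from compound 2 in more than one place and could not show this. Nothing shown accounts for the size of the step. Still open, going by these compounds, is how a pyridinyl ring, a plain phenyl ring or a piperidine would read on the same nitrogen. The step therefore cannot yet be divided between adding the ring nitrogens and losing the methoxy group.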